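The source may report more compounds than this note shows. Statements on the series, on what has been measured and on what is new or still open speak of the compounds shown alone.

Two compounds have so far been measured in an assay on isolated protein for displacement of a labelled ligand from metabotropic glutamate receptor 5 (Homo sapiens), with a stated time of 60 min, tested at 1 uM; on this read-out lower numbers stand for less inhibition and higher numbers for more inhibition at the one concentration tested (going by the name of the read-out):

compound 1 `CC1CCN(c2c(S(=O)(=O)c3ccccc3)cnc3cc(Cl)ccc23)CC1` gives 93%
compound 2 `CC1CCN(c2c(S(=O)(=O)c3cc(Cl)cc(Cl)c3)cnc3cc(Cl)ccc23)CC1` gives 93%

Compound 2 stands level with compound 1 at the digits shown. Going by the values given here, the single measured step, no change at the digits printed from compound 1 to compound 2 (within the scatter), put 3,5-dichlorophenyl in place of phenyl on the sulfonyl sulfur and left the inhibition unchanged within the scatter, so the two compounds cannot be ordered against each other.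

Compound 3 `Cc1ccc(S(=O)(=O)c2cnc3cc(Cl)ccc3c2N2CCC(C)CC2)cc1Cl` has not yet been measured. It differs from compound 2 in one place: 3-chloro-4-methylphenyl in place of 3,5-dichlorophenyl on a sulfonyl sulfur. Among the compounds with values here, the only measured step that bears on this change is the one already described, since it also exchanged the ring on the sulfonyl sulfur, and it was no larger than the scatter. Compound 3 is therefore expected to stay at the same high level of inhibition because compound 2 gives 93% after a comparable exchange. The expected step in this assay is a number 1 percentage points lower from compound 2 to compound 3 (within the scatter), nothing beyond the scatter. The estimate for compound 3 is 92%, with a range from 84% to 98%.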

Compound 3, a percentage reported as inhibition, at one concentration (the size of the read-out at that concentration, not a potency): 89%
The estimate for compound 3 lay 3 percentage points above the measured number; the range from low to high includes it.
By their numbers in this assay, from the lowest: compounds 3, 1 and 2 (each within the scatter of the next).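

In this assay the exchange on the sulfonyl sulfur gives a number 4 percentage points lower from compound 2 to compound 3 (within the scatter) and, set against the unsubstituted ring, a number 4 percentage points lower from compound 1 to compound 3 (within the scatter), so neither step separates compound 3 from the compound it is compared with. This extends the earlier finding to a third aryl group: 3-chloro-4-methylphenyl, which brings a methyl group onto the ring and keeps only one chlorine, reads alike with phenyl and 3,5-dichlorophenyl at this place, and the three compounds cannot be ordered by this read-out. No supporting measurement bears on why these groups read alike.

As far as these compounds go, because the read-out comes from a single concentration and says nothing of potency, any differences in potency among the three compounds remain open. From the compounds shown here alone, it also remains open whether this level would hold with a more different group on the sulfonyl sulfur, such as a ring carrying an amine or a carboxylic acid, or with a short alkyl chain in place of the aromatic ring.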